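From Cyclopropyl to Methoxyazetidine on the Carbonyl

This account rests on a few compounds, and the source may have more. Where it says the series, first, only, none or still open, it means among the compounds named here.

Compound 1 `CCn1c(-c2cnc(C)nc2)nc2c(O[C@H]3CCN(C(=O)C4CC4)C3)ncnc21` was tested in an ADME assay (Canis lupus familiaris, strain Beagle) for metabolic stability (a higher number here means that the compound lasts longer, a lower number that the compound disappears faster), where compound 1 gives 1.3 h. Within the data shown here, only one other compound has been measured: compound 2 `CCC(=O)N1CC[C@H](Nc2ncnc3c2nc(-c2cnc(C)nc2)n3CC)C1`, which in this assay gives 2.7 h. Compound 1 therefore holds the lower of the two numbers seen so far, and its gap to compound 2 lies beyond the usual scatter of the measurement. Among the measured compounds shown here, compounds 1 and 2 differ in more than one place, so no single structural step links them, and their two values say only that the shared core can reach either number.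

Compound 3 `CCn1c(-c2cnc(C)nc2)nc2c(O[C@H]3CCN(C(=O)N4CC(OC)C4)C3)ncnc21` has not yet been measured in this assay. It differs from compound 1 in one place: 3-methoxyazetidin-1-yl in place of cyclopropyl on a carbonyl carbon. For the measured compounds named here, nothing among the measured compounds shows what this particular change does. The expectation is therefore cautious. The step of a 1.2-fold higher number from compound 1 to compound 3 (0.06 log units; within the scatter) is expected to stay within the scatter, in either direction. Going by the values given here, compound 3 is estimated at 1.5 h, with a range from 0.7 h to 3.5 h, because compound 1 gives 1.3 h and no measured step argues for a larger move.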

Compound 3, half-life: 1.2 h
Compound 3: the middle estimate sits 1.3-fold (0.10 log units) above what was measured, within the range that was stated.
By their numbers in this assay, from the lowest: compounds 3 and 1 (each within the scatter of the next); then compound 2.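

Putting 3-methoxyazetidin-1-yl in place of cyclopropyl on the carbonyl carbon gives, in this assay, a 1.1-fold lower number from compound 1 to compound 3 (0.03 log units; within the scatter), so the two compounds cannot be told apart by this measurement. This position therefore tolerates a clear change in the group attached there: 6 heavy atoms enter where 3 leave, and a four-membered ring with a hetero atom and a hydrogen-bond acceptor takes the place of a three-membered ring of carbon only, with no shift in half-life beyond the scatter. Nothing in the data shown offers an explanation for this match between the two groups.

This is a single pair, so it says nothing yet about the methoxy group alone, and a plain azetidin-1-yl or a 3-hydroxyazetidin-1-yl on the same carbonyl carbon would be the direct way to separate the methoxy group's contribution from that of the ring. Also open, from the compounds shown here alone, is how far the tolerance reaches, for instance whether a dimethylamino group or a longer chain such as n-butyl at this place would keep the number within the scatter of compound 1.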